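This account rests on a few compounds, and the source may have more. Where it says the series, first, only, none or still open, it means among the compounds named here.

Measured so far in a functional assay on A549 cells (Homo sapiens) for cytotoxicity; a higher number here means that more compound is needed for the effect, a lower number that less compound is needed:
- Compound 1 `COc1cc(/C=C\c2ccc(C(C)(C)C)cc2)cc(OC)c1OC`: 1.02 uM
- Compound 2 `COc1cc(/C=C\c2ccc(C(C)C)cc2)cc(OC)c1OC`: 6.6 uM
- Compound 3 `CCOc1ccc(/C=C\c2cc(OC)c(OC)c(OC)c2)cc1`: 1.6 uM

Compound 3 stands close to compound 1, and a 1.6-fold higher number from compound 1 to compound 3 (0.20 log units; within the scatter) lies within the scatter, so the two cannot be told apart. Compound 2 is clearly separated from it, with a 4.1-fold lower number from compound 2 to compound 3 (0.62 log units; beyond the scatter).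

The next compound is compound 4 `COc1cc(/C=C\c2ccc(SC)cc2)cc(OC)c1OC`, which keeps the shared core of compound 3 and carries one change: methylsulfanyl in place of ethoxy on an aromatic carbon. The swap is methylsulfanyl in place of ethoxy on an aromatic carbon, para to a large group.

Going by the values given here, no measured compound carries methylsulfanyl, so no step bears on this change directly. The nearest evidence is the other swaps at this same place. Replacing tert-butyl with ethoxy gave a 1.6-fold higher number from compound 1 to compound 3 (0.20 log units; within the scatter), while the steps involving the isopropyl of compound 2 were modest: a 6.5-fold higher number from compound 1 to compound 2 (0.81 log units; beyond the scatter) and a 4.1-fold lower number from compound 2 to compound 3 (0.62 log units; beyond the scatter). Changes here can therefore matter, but only compound 2 stands apart from the others.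

With no direction supported, no shift beyond the scatter is expected in this assay. The expected step is a 1.1-fold lower number from compound 3 to compound 4 (0.03 log units; within the scatter), with a wide margin on both sides. For compound 4 the estimated value is 1.5 uM, with an expected range from 0.4 uM to 6 uM.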

Compound 4, concentration for half-maximal effect: 1.9 uM
For compound 4 the middle estimate is 1.3-fold (0.10 log units) below the measured one, within the range that was stated.
By their numbers in this assay, from the lowest: compounds 1, 3 and 4 (each within the scatter of the next); then compound 2.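

In this assay, methylsulfanyl joins ethoxy and tert-butyl as a third group at this place that cannot be told apart from the others, as both of its steps to them stay within the scatter (a 1.2-fold higher number from compound 3 to compound 4 (0.07 log units; within the scatter); a 1.9-fold higher number from compound 1 to compound 4 (0.27 log units; within the scatter)). The exchange of ethoxy, with 3 heavy atoms, for methylsulfanyl, with 2 heavy atoms and sulfur in place of oxygen, therefore leaves no readable trace in this set, and compound 2 with its isopropyl is now separated from a third compound at this place (a 3.5-fold lower number from compound 2 to compound 4 (0.54 log units; beyond the scatter)). Among the four groups compared here, isopropyl alone stands apart, and the data given offer no explanation for this or for the closeness of the other three.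

What these four compounds leave open is whether the closeness of the three groups extends to other kinds of group on this aromatic carbon, such as an amine, a carboxylic acid, a longer alkoxy chain or a methylsulfonyl group. They also leave open whether a group close to isopropyl, such as cyclopropyl or ethyl, would stand apart in the same way.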